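Lipophilicity of a lactam analogue

The compounds below may be only part of what the source reports. "The series", "measured", "known", "first", "only" and "open" are said of these compounds alone.

Compound 1 `CN(c1ncco1)c1cnc(NCc2c(F)ccc3c2CCO3)n2cnnc12`: 2.1
Compound 2 `O=C(Nc1cnc(NCc2c(F)ccc3c2CCO3)n2cnnc12)c1cccnc1`: 2

In a physicochemical assay for lipophilicity, using the shake flask method, in phosphate buffer, measured as octanol-water partition, with a stated time of 30 min, at pH 7.4 (a higher number here means a more lipophilic compound, a lower number a more polar compound), compound 2 gives 2, which lies within the scatter of compound 1. Compound 3 `O=C1CCCN1c1cnc(NCc2c(F)ccc3c2CCO3)n2cnnc12` has 2-oxopyrrolidin-1-yl in place of ((pyridin-3-yl)carbonyl)amino on an aromatic carbon. For the measured compounds named here, the one measured step touching this group, a number 0.10 log units lower from compound 1 to compound 2 (within the scatter), stayed within the scatter, but it does not measure this exact exchange. Only a small downward move is therefore expected, with the estimate being a number 0.30 log units lower from compound 2 to compound 3 (within the scatter). For compound 3 the estimated value is 1.7, with an expected range of 1.2 to 2.2.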

Compound 3, distribution coefficient: 1.3
The estimate for compound 3 lay 0.40 log units above the measured number; the measured number falls inside the stated range.
By their numbers in this assay, from the lowest: compound 3; then compounds 2 and 1 (each within the scatter of the next).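

In this assay, for the compounds shown here, the change at this aromatic carbon moves the number beyond the scatter for the first time: 2-oxopyrrolidin-1-yl gives a number 0.70 log units lower from compound 2 to compound 3 (beyond the scatter) and also a number 0.80 log units lower from compound 1 to compound 3 (beyond the scatter) when the comparison starts from methyl(1,3-oxazol-2-yl)amino. Compounds 1 and 2 remain within the scatter of each other, so compound 3 alone stands apart among the three. Nothing measured here accounts for this difference.

From the compounds shown here alone, it remains open whether an open-chain acetamide or a piperidin-2-one ring on this carbon would read like compound 3.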